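The compounds below may be only part of what the source reports. "The series", "measured", "known", "first", "only" and "open" are said of these compounds alone.

In a functional assay on MGC-803 cells (Homo sapiens) for cytotoxicity, read by MTT assay, with a stated time of 48 h (a higher number here means a weaker inhibitor, a lower number a stronger inhibitor), compound 1 (`CC1=NN(C(=O)CN2CCC(O)CC2)C(c2ccccc2O)C1`) gives 4120 nM, while compound 2 (`CCC1CCCCN1CC(=O)N1N=C(c2cc3ccccc3oc2=O)CC1c1ccccc1`) gives 8710 nM, the higher of the two numbers and thus the weaker inhibitor. Compound 3 (`CC1CCN(CC(=O)N2N=C(c3cc4ccccc4oc3=O)CC2c2ccccc2)CC1`) departs from compound 2 in one place: 4-methylpiperidin-1-yl in place of 2-ethylpiperidin-1-yl on a saturated chain carbon bound to a carbonyl carbon, with 4-methylpiperidin-1-yl in place of 2-ethylpiperidin-1-yl on a saturated chain carbon bound to a carbonyl carbon. Among the compounds with values here, no measured pair shows what such a change does in this assay. The estimated step is a 1.2-fold lower number from compound 2 to compound 3 (0.09 log units; within the scatter), a small one toward a lower number, expected to stay within the scatter. For compound 3 the expected value is 7000 nM, with an estimated range of 3000 nM to 16000 nM.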

Compound 3, half-maximal inhibitory concentration: 3010 nM
Compound 3: middle estimate off by 2.3-fold (0.37 log units), on the high side; low and high end bracket the measured number.
By their numbers in this assay, from the lowest: compounds 3 and 1 (each within the scatter of the next); then compound 2.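

In this assay, 4-methylpiperidin-1-yl in place of 2-ethylpiperidin-1-yl on a saturated chain carbon bound to a carbonyl carbon gives a 2.9-fold lower number from compound 2 to compound 3 (0.46 log units; beyond the scatter) and so shows that the assay responds to the substitution of this piperidine. Both groups have one six-membered non-aromatic ring and no net charge, but this single pair cannot separate the change of substituent from the change of its place on the ring. No supporting data explain the shift. From the compounds shown here alone, what a 2-methylpiperidin-1-yl group, a 4-ethylpiperidin-1-yl group or a morpholine would do here remains open.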